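The compounds below may be only part of what the source reports. "The series", "measured", "known", "first", "only" and "open" are said of these compounds alone.

Measured compounds:
- Compound 1, `CC(C)n1ncc2c(C(=O)Nc3cccnc3)cc(-c3cccs3)nc21`, in an ADME assay on LLC-MK2 cells (Macaca mulatta) for cytotoxicity, read by spectrophotometry and crystal violet staining, with a stated time of 4 days (a higher number here means that more compound is tolerated, a lower number that less compound is tolerated), gives > 200000 nM, which is a limit of the assay and not a number.
- Compound 2, `CC(C)n1ncc2c(C(=O)Nc3ccc(F)cc3)cc(-c3cccs3)nc21`, gives > 200000 nM, again a limit of the assay.
- Compound 3, `CC(C)n1ncc2c(C(=O)Nc3ccccc3S(N)(=O)=O)cc(-c3cccs3)nc21`, gives 25000 nM.

Among the compounds with values here, compound 3 therefore stands as the only actual number among the three; the picture is otherwise shaped by the limit of > 200000 nM in this assay, at which 2 of the 3 values shown sit. The step of an at least 8.0-fold lower number from compound 1 to compound 3 (0.90 log units; beyond the scatter) and the step of an at least 8.0-fold lower number from compound 2 to compound 3 (0.90 log units; beyond the scatter) are both beyond the scatter, while the step that the two limits leave unreadable from compound 1 to compound 2 cannot be read from the two limits.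

Compound 4, `CC(C)n1ncc2c(C(=O)Nc3ccc(F)cc3F)cc(-c3cccs3)nc21`, has not yet been measured. The change from compound 3 is 2,4-difluorophenyl in place of 2-sulfamoylphenyl on an amide-type nitrogen. The step that bears on it most directly is an at least 8.0-fold lower number from compound 2 to compound 3 (0.90 log units; beyond the scatter), which goes from a fluorophenyl amide to the sulfamoylphenyl amide; compound 4 runs that step backwards to a fluorinated phenyl amide, so the expectation is a return towards the limit.

Compound 4 is therefore expected to give 200000 nM, with a range of 60000 nM to 600000 nM. That expectation amounts to a step of an 8.0-fold higher number from compound 3 to compound 4 (0.90 log units; beyond the scatter), and it is likely that the assay again reports only a limit.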

Compound 4, half-maximal cytotoxic concentration: > 200000 nM
Compound 4: only a limit was reported; the forecaster's own chance of this, stated with the estimate: 70%; the middle value sits exactly at the limit.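

Compound 4 brings a third group without the sulfamoyl function to this place on an amide-type nitrogen, and in this assay the change to 2,4-difluorophenyl gives an at least 8.0-fold higher number from compound 3 to compound 4 (0.90 log units; beyond the scatter). Pyridin-3-yl in compound 1, 4-fluorophenyl in compound 2 and 2,4-difluorophenyl in compound 4 now all end at the same reading, and only the 2-sulfamoylphenyl group of compound 3 departs from it, so the lower number is tied among these compounds to that one group, with the reading still set by a single ceiling: the limit of > 200000 nM in this assay, at which 3 of the 4 values shown sit. The steps among compound 1, compound 2 and compound 4 cannot be read, including the added fluoro on the aromatic carbon, as the values at both ends of each are limits of the assay and not numbers.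

On these data alone, it stays open whether the lower number in compound 3 belongs to the sulfamoyl group alone, or whether a carboxylic acid or an amine on the same phenyl ring would lower it as well. The isopropyl group and the rest of the shared core stay the same throughout, so what changes there would do in this assay is also unknown.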